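Benzofuran in place of furan on compound 2

A few compounds are considered here, and "the series" means these few. Any claim that something is new, unique, unknown or untested is made for them only; others in the source may bear on it.

Compound 1 `C#Cc1cn([C@@H]2O[C@H](CO)[C@@H](O)[C@H]2O)c2ncnc(SC)c12` gives 68600 nM
Compound 2 `CNc1ncnc2c1c(-c1ccco1)cn2[C@@H]1O[C@H](CO)[C@@H](O)[C@H]1O` gives 5040 nM

In an ADME assay on BJ cells (Homo sapiens), read by MTT assay, with a stated time of 72 h (on this read-out higher numbers stand for weaker inhibition and lower numbers for stronger inhibition), compound 2 stands lowest of the two measured compounds at 5040 nM. Compound 1 stands at 68600 nM. The gap between these two values lies beyond the scatter. Compound 3 `CNc1ncnc2c1c(-c1cc3ccccc3o1)cn2[C@@H]1O[C@H](CO)[C@@H](O)[C@H]1O` carries 1-benzofuran-2-yl in place of furan-2-yl on an aromatic carbon of compound 2 (1-benzofuran-2-yl in place of furan-2-yl on an aromatic carbon). Among the measured compounds shown here, no measured pair differs in only one place, so the expectation is loose. A modest move to a higher number in this assay is expected, with an estimated 1.6-fold higher number from compound 2 to compound 3 (0.20 log units; within the scatter). The estimate for compound 3 is 8000 nM, with an expected range from 2000 nM to 40000 nM.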

Compound 3, half-maximal inhibitory concentration: 75600 nM
Compound 3: the middle estimate sits 9.5-fold (0.98 log units) below what was measured; measured number above the stated range.
By their numbers in this assay, from the lowest: compound 2; then compounds 1 and 3 (each within the scatter of the next).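

In this assay, the aromatic carbon two ring bonds from the ring nitrogen proves sensitive to the ring attached there: 1-benzofuran-2-yl in place of furan-2-yl gives a 15-fold higher number from compound 2 to compound 3 (1.18 log units; beyond the scatter) and so weakens inhibition markedly. The extra six-membered aromatic ring of carbon only is thus not neutral at this position on this core. No available evidence bears on the reason for this step. The compounds shown leave open how thiophen-2-yl or a plain phenyl ring on this carbon would read in this assay.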